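Swapping Methylsulfanyl for Bromo in a Level Pair

The source may report more compounds than this note shows. Statements on the series, on what has been measured and on what is new or still open speak of the compounds shown alone.

Among the compounds with values here, in a functional assay on DU-145 cells (Homo sapiens) for inhibition, read by trypan blue exclusion, with a stated time of 96 h (on this read-out higher numbers stand for weaker inhibition of growth and lower numbers for stronger inhibition of growth), compound 1 `Cc1ccc(CS/C(=C/c2ccc(F)c(C)c2)C(=O)c2ccc(Cl)cc2)cc1` reads 25000 nM and compound 2 `CSc1ccc(/C=C(/SCc2ccc(C)cc2)C(=O)c2ccc(Cl)cc2)cc1` reads 25000 nM in the same test, so compound 2 stands level with compound 1, its only measured neighbour. Compound 3 `Cc1ccc(CS/C(=C/c2ccc(Br)cc2)C(=O)c2ccc(Cl)cc2)cc1` keeps the shared core and carries one change bromo in place of methylsulfanyl on an aromatic carbon in which bromo takes the place of methylsulfanyl on an aromatic carbon, para to a large group. Within the data shown here, only one measured step bears on this. It shows no change at the digits printed from compound 1 to compound 2 (within the scatter) when 4-(methylsulfanyl)phenyl replaced 4-fluoro-3-methylphenyl at the same place in the molecule. Among the measured compounds shown here, that is thin evidence, since it is a single step and no bromo compound has been measured yet. Even so, it offers no reason to predict a large move, so no shift beyond the scatter is expected in this assay for this swap. The expected size is a 1.3-fold lower number from compound 2 to compound 3 (0.10 log units; within the scatter) on this reasoning, with no firm direction behind it. For compound 3 the estimate is 20000 nM with a range from 7000 nM to 30000 nM as the expected bounds.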

Compound 3, concentration for 50% growth inhibition: 10000 nM
Compound 3: the middle estimate sits 2.0-fold (0.30 log units) above what was measured; measured number inside the range.
By their numbers in this assay, from the lowest: compound 3; then compounds 1 and 2 (each within the scatter of the next).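

In this assay, within the data shown here, the change of methylsulfanyl to bromo, on an aromatic carbon para to a large group, gives a 2.5-fold lower number from compound 2 to compound 3 (0.40 log units; beyond the scatter) and is the first step in this small set to pass beyond the scatter. The same gain in growth inhibition appears when 4-bromophenyl replaces 4-fluoro-3-methylphenyl, with a 2.5-fold lower number from compound 1 to compound 3 (0.40 log units; beyond the scatter) on that comparison, so compound 3 separates from both earlier compounds, which could not be told apart, and this aromatic ring is shown to be able to move the read-out, though only modestly. Nothing measured here indicates what lies behind this gain.

Going by these compounds, with a single bromo compound, it remains open whether the gain is particular to bromo or would also be seen with another group on the same aromatic carbon, such as iodo, an amine or a carboxylic acid. On these data alone, it is also open whether the same swap would give a similar step on a different version of the shared core, for example one with a group other than 4-chlorophenyl on the carbonyl.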